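A few compounds are considered here, and "the series" means these few. Any claim that something is new, unique, unknown or untested is made for them only; others in the source may bear on it.

Measured in a functional assay for inhibition, with Homo sapiens as the target; a higher number here means a weaker inhibitor, a lower number a stronger inhibitor:
- compound 1 `Fc1cccc(Nc2nccc(-c3ccccn3)n2)c1` gives 1000 nM
- compound 2 `CN(C)c1cccc(Nc2nccc(-c3ccccn3)n2)c1` gives 400 nM
- compound 3 `c1ccc(-c2ccnc(Nc3cccc(OCCn4ccnc4)c3)n2)nc1` gives 400 nM

Compound 2 stands level with compound 3, and together they hold the lowest number of the three. Compound 4 `CN(C)c1cccc(Nc2nccc(-c3ccncc3)n2)c1` differs from compound 2 in one group, with pyridin-4-yl in place of pyridin-2-yl on an aromatic carbon. For the measured compounds named here, no measured step touches this group. The steps available change a different group: a 2.5-fold lower number from compound 1 to compound 2 (0.40 log units; beyond the scatter) and a 2.5-fold lower number from compound 1 to compound 3 (0.40 log units; beyond the scatter), both modest, and no change at the digits printed from compound 2 to compound 3 (within the scatter). They give no direction for the new change, so no step beyond the scatter is expected in this assay, though with wide uncertainty. The expected step is no change at the digits printed from compound 2 to compound 4 (within the scatter). Compound 4 is estimated at 400 nM, with an expected range of 80 nM to 2000 nM.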

Compound 4, half-maximal inhibitory concentration: 3700 nM
Compound 4: the middle estimate sits 9.3-fold (0.97 log units) below what was measured; the measured number lies above the stated range.
By their numbers in this assay, from the lowest: compounds 2 and 3 (each within the scatter of the next); then compound 1; then compound 4.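

In this assay, pyridin-4-yl in place of pyridin-2-yl gives a 9.3-fold higher number from compound 2 to compound 4 (0.97 log units; beyond the scatter), the first measured sign that this position responds to change. The two groups have the same atoms and the same counts, so merely moving the attachment point within the ring is enough to weaken inhibition. No measurement here explains this loss.

From the compounds shown here alone, it remains open how pyridin-3-yl or a plain phenyl ring would fare at this position. Also open, going by these compounds, is whether pyridin-4-yl would weaken inhibition alongside the 2-(1H-imidazol-1-yl)ethoxy group of compound 3.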